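The source may hold more compounds than are shown below. What is called first, only, known or untested is meant among the compounds shown, and "the series" means these compounds.

Values in an ADME assay on Vero cells (Chlorocebus sabaeus) for cytotoxicity, read by reporter gene assay, with a stated time of 4 days (a lower number here means a stronger inhibitor, a higher number a weaker inhibitor), so far:
compound 1 `CCCCCCC(=O)OCC(C)(C)CC1=C(O)C(=O)c2ccccc2C1=O` gives 99300 nM
compound 2 `CCCCCCCCCCC(=O)OCC(C)(C)CC1=C(O)C(=O)c2ccccc2C1=O` gives > 233000 nM
compound 3 `CCCCCCCCCCCC(=O)OCC(C)(C)CC1=C(O)C(=O)c2ccccc2C1=O` has not yet been measured

For compound 2 the reading > 233000 nM is a limit of the assay and not a number. The next compound differs from it by methyl in place of hydrogen on a saturated chain carbon, ten or more bonds along the chain from a carbonyl carbon. Within the data shown here, one measured step bears on this change. The step of an at least 2.3-fold higher number from compound 1 to compound 2 (0.37 log units; beyond the scatter) is an addition to the same chain, butyl in place of hydrogen, and it lies beyond the scatter. Its size is only a bound, as compound 2 has no numerical value. Methyl is a smaller addition than that butyl, so no shift beyond the scatter is expected in this assay, and any movement would more likely be towards a higher number. The expected step is an at least 1.0-fold lower number from compound 2 to compound 3 (0.00 log units; that floor lies within the scatter) and would stay within the scatter. For compound 3 the estimated value is 230000 nM with an expected range from 110000 nM to 400000 nM and a report as a limit alone is quite likely.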

Compound 3, half-maximal inhibitory concentration: 249000 nM
Compound 3: middle estimate off by 1.1-fold (0.03 log units), on the low side; measured number inside the range.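

In this assay the series now has its first fully numerical chain-length comparison: a 2.5-fold higher number from compound 1 to compound 3 (0.40 log units; beyond the scatter). Compound 3 gives 249000 nM, so the longer end of this set of esters now has a measured number. The effect of the added methyl cannot be read, because compound 2 is reported only as a limit and not a number: the limit of > 233000 nM in this assay, at which 1 of the 3 values shown sits.

As far as these compounds go, with only compound 1 and compound 3 as numerical points, no trend across chain length can be drawn, and the shape of the change between them remains unknown. From the compounds shown here alone, whether the higher number in this assay would hold for a longer chain, or for a chain carrying an amine or a carboxylic acid, stays open.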